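The source may hold more compounds than are shown below. What is called first, only, known or untested is meant among the compounds shown, and "the series" means these compounds.

Measured compounds:
compound 1 `c1ccc(Cn2nnc3c(NC4CCCCC4)ncnc32)cc1` gives 121 nM in an assay on cell membranes for binding affinity to adenosine receptor A1 (Bos taurus), read by radioligand binding; on this read-out lower numbers stand for stronger inhibition and higher numbers for weaker inhibition
compound 2 `CC1CCCC(Nc2ncnc3c2nnn3Cc2ccccc2Cl)C1` gives 102 nM
compound 3 `Cc1ccc(Nc2ncnc3c2nnn3Cc2ccccc2Cl)cc1` gives 119 nM

All three numbers come from this assay. Compound 1 lies within the usual scatter of compound 3 and of compound 2, so no ordering among the three can be read from these numbers. The unmeasured compound 4 `Cc1cccc(Nc2ncnc3c2nnn3Cc2ccccc2)c1` differs from compound 1 in one place: 3-methylphenyl in place of cyclohexyl on a nitrogen on an aromatic ring. Going by the values given here, one measured step bears on this change: a 1.2-fold higher number from compound 2 to compound 3 (0.07 log units; within the scatter), where a non-aromatic ring of carbon only carrying a methyl group was likewise replaced by an aromatic ring of carbon only carrying a methyl group, on a nitrogen on an aromatic ring; that step stayed within the scatter. Because this comparison a 1.2-fold higher number from compound 2 to compound 3 (0.07 log units; within the scatter) is the only one of its kind here, the expectation rests on it alone, and the step from compound 1 to compound 4 is expected to be of similar size, that is none beyond the scatter, a 1.0-fold lower number from compound 1 to compound 4 (0.00 log units; within the scatter). Compound 4 is therefore estimated at 120 nM in this assay, with a range from 50 nM to 300 nM.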

Compound 4, inhibition constant: 1100 nM
Beside the measured number, compound 4's estimate is 9.2-fold (0.96 log units) below it, and the stated range ends below it.
By their numbers in this assay, from the lowest: compounds 2, 3 and 1 (each within the scatter of the next); then compound 4.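

In this assay, going by these compounds alone, placing 3-methylphenyl instead of cyclohexyl on the nitrogen gives a 9.1-fold higher number from compound 1 to compound 4 (0.96 log units; beyond the scatter), the first step in this set that clearly exceeds the scatter. Within the data shown here, it shows that this position does not tolerate every ring swap equally: the only earlier step of this kind, a 1.2-fold higher number from compound 2 to compound 3 (0.07 log units; within the scatter), stayed within the scatter, so the same type of swap can come out differently in a related pair. The two pairs differ in more than one way, since compounds 2 and 3 carry a chlorine that compounds 1 and 4 lack and their methyl groups are named at different ring positions, and no available evidence explains why the two steps differ.

The compounds shown leave open whether the higher number in compound 4 comes from the aromatic ring itself or from its methyl group, a question that a plain phenyl on the same nitrogen of the core of compound 1 would address. They also leave open how an open-chain group such as hexyl at this position would compare, and whether adding the chlorine to compound 4 would change its number.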